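This account rests on a few compounds, and the source may have more. Where it says the series, first, only, none or still open, it means among the compounds named here.

In a functional assay on the whole organism (Tail, strain ICR) with Mus musculus as the target, in the tail flick test, with a stated time of 120 min, at a dose of 25 umol/kg by the oral route (a higher number here means a stronger effect of the compound at the dose given, a lower number a weaker effect), compound 2 `O=C(CN(c1ncnc2c1ncn2C1CCCCO1)C1CC1)N[C@@H](CCC(=O)OCc1ccccc1)C(=O)OCc1ccccc1` gives 20.7%, the lower of the two numbers shown, while compound 1 `O=C(CN(c1nc(Cl)nc2[nH]cnc12)C1CC1)NCC(=O)OCc1ccccc1` gives 21.7%, a value within the scatter of it, so the two cannot be told apart. Compound 3 `CC(C)C[C@H](NC(=O)CN(c1ncnc2c1ncn2C1CCCCO1)C1CC1)C(=O)OCc1ccccc1` differs from compound 2 in one place: isopropyl in place of (benzyloxycarbonyl)methyl on a saturated chain carbon, two bonds along the chain from an amide-type nitrogen and a carbonyl carbon. For the measured compounds named here, no measured pair shows a change of this kind, so the step expected from compound 2 to compound 3 in this assay is a number 1.3 percentage points higher from compound 2 to compound 3 (within the scatter), which amounts to none beyond the scatter. Compound 3 is therefore expected to give about 22% in this assay, between 8% and 38%.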

Compound 3, a percentage reported as activity, at one dose (the size of the read-out at that dose, not a potency): 12.8%
For compound 3 the middle estimate is 9.2 percentage points above the measured one; low and high end bracket the measured number.
By their numbers in this assay, from the lowest: compounds 3, 2 and 1 (each within the scatter of the next).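

In this assay, putting isopropyl in place of (benzyloxycarbonyl)methyl gives a number 7.9 percentage points lower from compound 2 to compound 3 (within the scatter) and so no change that can be read, even though the six-membered aromatic ring and both hydrogen-bond acceptors of the leaving group are gone. At this position, then, a group of 11 heavy atoms gives way to one of 3 without a difference that can be told from the scatter. No measurement at hand accounts for this result. On these data alone, whether a carboxylic acid, an amine or a longer chain on this saturated chain carbon would move the number beyond the scatter remains open.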